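The source may report more compounds than this note shows. Statements on the series, on what has been measured and on what is new or still open speak of the compounds shown alone.

Working notes on the series. Compound 1 `CC(=O)Nc1ccc(S(=O)(=O)NNC(=O)c2cccnc2Nc2ccc(Cl)cc2)cc1` was tested in a functional assay on HCT-116 cells (Homo sapiens) for antiproliferative activity; a higher number here means that more compound is tolerated, a lower number that less compound is tolerated. In this assay compound 1 gives > 100000 nM, which is a limit of the assay and not a number. Compound 2 `O=C(NNS(=O)(=O)c1ccc(F)cc1)c1cccnc1Nc1ccc(Cl)cc1Cl` was tested in the same way. In this assay compound 2 gives > 100000 nM, again a limit of the assay rather than a number. Both values shown so far therefore sit at the same point: the limit of > 100000 nM in this assay, at which 2 of the 2 values shown sit. Compound 1 thus stands at the limit of what was measured, with no number to place it against. Compound 3 `O=C(NNS(=O)(=O)c1ccc(Cl)cc1Cl)c1cccnc1Nc1ccc(Cl)cc1` is not yet measured in this assay. It differs from compound 1 in one place: 2,4-dichlorophenyl in place of 4-acetamidophenyl on a sulfonyl sulfur. Within the data shown here, no step between measured compounds is available, so no size for this change can be read from the series. The expected step from compound 1 to compound 3 is a number no higher from compound 1 to compound 3 (the limit leaves the size open), none beyond the scatter. Compound 3 is expected to give about 100000 nM in this assay, with a range from 30000 nM to 300000 nM, most likely reported once more as a limit.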

Compound 3, concentration lethal to 50% of the cells: 53700 nM
Compound 3: the middle estimate sits 1.9-fold (0.27 log units) above what was measured; the range from low to high includes it.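

In this assay, among these compounds, compound 3 is the first compound to give a number rather than a limit, which shows that a change on a sulfonyl sulfur alone can bring a value inside the measured range. Going by these compounds, the change from 4-acetamidophenyl to 2,4-dichlorophenyl gives an at least 1.8-fold lower number from compound 1 to compound 3 (0.27 log units; that floor lies within the scatter), so only a floor can be read and the true size of the step stays open. Compound 3 therefore holds the only number that later steps can start from, as the other values are limits: the limit of > 100000 nM in this assay, at which 2 of the 3 values shown sit.

On these data alone, whether the number in compound 3 follows from the chlorine atoms, from one of them alone, or from the loss of the acetamido group stays open. How a plain phenyl, a 4-aminophenyl or a short alkyl chain on a sulfonyl sulfur would stand in this assay is also unknown.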